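This account rests on a few compounds, and the source may have more. Where it says the series, first, only, none or still open, it means among the compounds named here.

Measured in an ADME assay on THP-1 cells (Homo sapiens) for cytotoxicity; a lower number here means that less compound is tolerated, a higher number that more compound is tolerated:
- Compound 1 `COC(=O)Nc1sc2c(c1C(=O)Nc1ccc(OC)cc1)CCCCC2`: > 50000 nM
- Compound 2 `O=C(Nc1ccc(Cl)cc1)c1c(NC(=O)C(F)(F)F)sc2c1CCCCC2`: > 50000 nM
- Compound 3 `COc1ccc(NC(=O)c2c(NC(=O)C(F)(F)F)sc3c2CCC3)cc1`: > 50000 nM

All three entries are limits of the assay, not numbers: the limit of > 50000 nM in this assay, at which 3 of the 3 values shown sit. Compound 2 therefore has no exact position in the series, only its limit of > 50000 nM. Among the compounds with values here, no measured pair differs in one place, so the series offers no step to use as a guide.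

Compound 4 `O=C(Nc1ccc(OC(F)(F)F)cc1)c1c(NC(=O)C(F)(F)F)sc2c1CCCCC2` has trifluoromethoxy in place of chloro on an aromatic carbon, para to a large group: trifluoromethoxy in place of chloro on an aromatic carbon. Starting from compound 2 at > 50000 nM, which is a limit, no step beyond the scatter is expected in this assay, in either direction. The expected change is a number no higher from compound 2 to compound 4 (the limit leaves the size open). For compound 4 the estimate is 50000 nM, with an expected range from 20000 nM to 50000 nM.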

Compound 4, half-maximal cytotoxic concentration: 11900 nM
Estimate against measurement, compound 4: 4.2-fold (0.62 log units) above; measured number below the stated range.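

In this assay, trifluoromethoxy in place of chloro on an aromatic carbon, para to a large group, gives an at least 4.2-fold lower number from compound 2 to compound 4 (0.62 log units; beyond the scatter) and the step lies beyond the scatter. This position therefore affects the read-out, and compound 4 is the only compound shown with a number rather than a limit. The size of the step stays open-ended because the value of compound 2 is a limit: the limit of > 50000 nM in this assay, at which 3 of the 4 values shown sit.

From the compounds shown here alone, whether a nitrile or an amine at this position would also lower the number remains open. So does whether the same change would act alike on the core of compound 3.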